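Chloro on the thiazole phenyl of a nitrile core

The compounds below may be only part of what the source reports. "The series", "measured", "known", "first", "only" and "open" are said of these compounds alone.

Compound 1, `COc1ccc(-c2nc(SCC(=O)c3sc(-c4ccccc4)nc3C)[nH]c(=O)c2C#N)cc1`: 1.08%
Compound 2, `Cc1nc(-c2ccccc2)sc1C(=O)CSc1nc(-c2ccc(Cl)c(Cl)c2)c(C#N)c(=O)[nH]1`: 24.4%
Compound 3, `Cc1nc(-c2ccccc2)sc1C(=O)CSc1nc(-c2cccc(Cl)c2)c(C#N)c(=O)[nH]1`: 10%

In a functional assay on U-87MG ATCC cells for antiproliferative activity against U-87 MG (Homo sapiens), read by MTT assay, with a stated time of 48 h, tested at 100 uM (on this read-out higher numbers stand for a weaker effect at the one concentration tested and lower numbers for a stronger effect), compound 1 gives the lowest of the three numbers. Compound 3 lies nearest to it, a gap that stays within the scatter, while compound 2 lies furthest, and the step of a number 23.3 percentage points higher from compound 1 to compound 2 (beyond the scatter) is beyond the scatter. Compound 4, `COc1ccc(-c2nc(SCC(=O)c3sc(-c4ccc(Cl)cc4)nc3C)[nH]c(=O)c2C#N)cc1`, is not yet measured; it differs from compound 1 by chloro in place of hydrogen on an aromatic carbon.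

Among the measured compounds shown here, none of the measured steps touches this phenyl. The steps of a number 23.3 percentage points higher from compound 1 to compound 2 (beyond the scatter) and a number 8.9 percentage points higher from compound 1 to compound 3 (within the scatter) replace the 4-methoxyphenyl on the shared core with chlorinated phenyls, and the step of a number 14.4 percentage points lower from compound 2 to compound 3 (beyond the scatter) removes one chloro from that same ring. They show that bringing chloro into a phenyl of this core moved the read-out in this assay upward by a modest amount at most, and in one case by an amount within the scatter. The change in compound 4 sits on a different ring, so these steps bear on it only loosely.

Compound 4 is therefore expected to give 6%, between 0% and 20%, a step of a number 4.9 percentage points higher from compound 1 to compound 4 (within the scatter) that is estimated to stay within or just beyond the scatter.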

Compound 4, a percentage reported as activity, at one concentration (the size of the read-out at that concentration, not a potency): 16.6%
Beside the measured number, compound 4's estimate is 10.6 percentage points below it, within the range that was stated.
By their numbers in this assay, from the lowest: compounds 1, 3, 4 and 2 (each within the scatter of the next, the first and the last beyond it).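

In this assay, the change from phenyl to 4-chlorophenyl, the first to touch this ring, gives a number 15.5 percentage points higher from compound 1 to compound 4 (beyond the scatter). Among the compounds shown here, this shows that the position is not indifferent: a single chloro, placed para to a large group on a ring that no earlier step had changed, shifts the read-out towards a weaker effect at the one concentration tested, by a modest amount. The earlier steps had shown the effect of chloro only on the other phenyl, and the size now seen on this ring matches the size seen there, so the exchange of hydrogen and chloro reads much the same in both settings: the same change on two cores in this assay, a number 14.4 percentage points lower (beyond the scatter) from compound 2 to compound 3 and a number 15.5 percentage points lower (beyond the scatter) from compound 4 to compound 1, 1.1 percentage points apart, within the scatter of two such steps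

Going by these compounds, what an amine, a carboxylic acid or a longer chain would do in place of the chloro at this position remains open, as does whether chloro on both phenyls would add up on the shared core. With a single concentration behind each number, the compounds shown also leave open how these steps would appear as differences in potency.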